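A few compounds are considered here, and "the series" means these few. Any claim that something is new, unique, unknown or untested is made for them only; others in the source may bear on it.

Compound 1 `Nc1ccccc1NC(=O)CCCCCCc1nc(-c2ccccc2)no1` is the starting point. In a functional assay on U-937 cells (Homo sapiens) for antiproliferative activity, read by MTT assay, with a stated time of 72 h (a lower number here means a stronger inhibitor, a higher number a weaker inhibitor), compound 1 gives 730 nM.

Compound 2 `Nc1ccccc1NC(=O)CCCCCCc1nc(-c2cccc([N+](=O)[O-])c2)no1` differs from compound 1 in one place: nitro in place of hydrogen on an aromatic carbon. The effect of this change is a step of a 2.9-fold higher number from compound 1 to compound 2 (0.47 log units; beyond the scatter), and in this assay compound 2 gives 2150 nM.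

Compound 3 `O=C(CCCCCCc1nc(-c2ccccc2)no1)C(F)(F)F` differs from compound 1 at the other end of the chain: trifluoromethyl in place of (2-aminophenyl)amino on a carbonyl carbon. This is the difference between the two cores. The step is a 1.8-fold lower number from compound 1 to compound 3 (0.25 log units; within the scatter), so the two readings are not distinguishable here. In this assay compound 3 gives 410 nM.

Compound 4 `O=C(CCCCCCc1nc(-c2cccc([N+](=O)[O-])c2)no1)C(F)(F)F` has not yet been measured. It differs from compound 3 by nitro in place of hydrogen on an aromatic carbon, the same change that was made from compound 1 to compound 2, and at the same place on the ring. Among the measured compounds shown here, the only guide to how compound 4 will behave is the measured step from compound 1 to compound 2, which weakened the inhibitor modestly. Carrying that step over onto the core of compound 3 is an assumption, as the change has been seen only once. On that basis the step from compound 3 to compound 4 is expected to be about a 2.9-fold higher number from compound 3 to compound 4 (0.47 log units; beyond the scatter), resting on a 2.9-fold higher number from compound 1 to compound 2 (0.47 log units; beyond the scatter). In this assay compound 4 is therefore estimated at 1200 nM, with a plausible span from 600 nM to 2500 nM.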

Compound 4, half-maximal inhibitory concentration: 560 nM
Compound 4: middle estimate off by 2.1-fold (0.33 log units), on the high side; measured number below the stated range.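

In this assay, placing nitro on the ring of the core of compound 3 gives a 1.4-fold higher number from compound 3 to compound 4 (0.14 log units; within the scatter), and this step can be set directly against the same change on the core of compound 1: the same change on two cores in this assay, a 2.9-fold higher number (0.47 log units; beyond the scatter) from compound 1 to compound 2 and a 1.4-fold higher number (0.14 log units; within the scatter) from compound 3 to compound 4, 2.2-fold (0.33 log units) apart, within the scatter of two such steps The reverse view, exchanging the (2-aminophenyl)amino group for trifluoromethyl on the nitro-bearing compounds, gives a 3.8-fold lower number from compound 2 to compound 4 (0.58 log units; beyond the scatter), and this agrees with the earlier exchange no less well: the same change on two cores in this assay, a 1.8-fold lower number (0.25 log units; within the scatter) from compound 1 to compound 3 and a 3.8-fold lower number (0.58 log units; beyond the scatter) from compound 2 to compound 4, 2.2-fold (0.33 log units) apart, within the scatter of two such steps So neither change shows a measurable dependence on the core it is made on, but this does not prove that the changes carry over exactly, as each has been seen on just two cores, and a real difference of this size could be hidden in the scatter; the nitro step also stands clear of the scatter on the core of compound 1 only.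

The compounds shown leave open whether this agreement extends to other groups on the ring, such as an amine or a carboxylic acid in place of nitro. They also leave open whether it would hold with a longer chain in either core.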